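The source may hold more compounds than are shown below. What is called first, only, known or untested is meant among the compounds shown, and "the series" means these compounds.

Working notes on the series.

Three compounds of the shared core have been run in a functional assay on HEK293 cells for agonist activity at probable G-protein coupled receptor 27 (Homo sapiens), read by a luciferase reporter and beta-arrestin recruitment, with a stated time of 10 min; a higher number here means a larger maximal response, a lower number a smaller maximal response. Compound 1 `Cc1cc(Cl)ccc1C(=O)Nc1ccc(S(=O)(=O)Nc2ccccc2)cc1` gives 123%. Compound 2 `O=C(Nc1ccc(S(=O)(=O)Nc2ccccc2)cc1)c1ccc(Cl)cc1Cl` gives 100%. Compound 3 `O=C(Nc1ccc(S(=O)(=O)Nc2ccccc2Cl)cc1)c1ccc(Cl)cc1Cl` gives 53%, the lowest of the three, and its nearest neighbour by value is compound 2.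

The two measured steps point in opposite directions. From compound 2 to compound 1 the change is methyl in place of chloro on an aromatic carbon, and this brings a number 23 percentage points higher from compound 2 to compound 1 (beyond the scatter). From compound 2 to compound 3 the change is chloro in place of hydrogen on an aromatic carbon, and this brings a number 47 percentage points lower from compound 2 to compound 3 (beyond the scatter).

Compound 4 `Cc1ccccc1NS(=O)(=O)c1ccc(NC(=O)c2ccc(Cl)cc2Cl)cc1` has not yet been measured. It differs from compound 3 by methyl in place of chloro on an aromatic carbon. Going by the values given here, this is the same kind of change as the one from compound 2 to compound 1, but not the same: there the place was ortho to a large group and meta to a chloro group, here it is ortho to a large group only, and the two cores themselves differ by chloro in place of hydrogen on an aromatic carbon.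

Among the compounds with values here, only one earlier instance of this kind of change exists, the step of a number 23 percentage points higher from compound 2 to compound 1 (beyond the scatter), so the expectation rests on that single pair. For compound 4 a step of a number 22 percentage points higher from compound 3 to compound 4 (beyond the scatter) is expected in this assay, of a size similar to the earlier one. Compound 4 is therefore estimated at 75%, with a range from 50% to 105%, because compound 3 starts from 53%.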

Compound 4, largest response reached (Emax), in percent of the reference or control that the assay uses: 32%
Compound 4: middle estimate off by 43 percentage points, on the high side; measured number outside the range, below it.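

In this assay, methyl in place of chloro on an aromatic carbon does not carry a fixed step from one core to the other, and even the direction of the step reverses: the same change on two cores in this assay, a number 23 percentage points higher (beyond the scatter) from compound 2 to compound 1 and a number 21 percentage points lower (beyond the scatter) from compound 3 to compound 4, 44 percentage points apart, beyond the scatter of two such steps

On the core of compound 3, the change gives a number 21 percentage points lower from compound 3 to compound 4 (beyond the scatter), while methyl in place of hydrogen at the same place, ortho to a large group, gives a number 68 percentage points lower from compound 2 to compound 4 (beyond the scatter), so among the compounds shown, both chloro and methyl at this place go with a lower maximal response than the hydrogen of compound 2. The change stands at a different place in each pair and the cores differ as well, so these two pairs cannot tell whether the place or the rest of the core sets the direction, and they give no cause for the reversal.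

Left open is how other groups at this place, such as a methoxy group, an amine or a carboxylic acid, would read in this assay, and whether any of them would match hydrogen. Also open, on these data alone, is whether the gain seen with methyl on the core of compound 2 would recur at the other chloro of that ring.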